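Carbamoyl in Place of Nitro: Expected Antiproliferative Potency

The source may hold more compounds than are shown below. What is called first, only, known or untested is meant among the compounds shown, and "the series" means these compounds.

The study follows a small set of compounds in a functional assay on L1210 cells (Mus musculus) for antiproliferative activity; on this read-out lower numbers stand for lower potency and higher numbers for higher potency (the scale is a negative logarithm). Compound 1 `CCCN(C)/N=N/c1ccccc1C(N)=O` gives 3.26 in this assay. Compound 2 `CN(C)/N=N/c1ccccc1[N+](=O)[O-]` gives 3.28 in this assay, a number within the scatter of compound 1, so the two cannot be told apart on this read-out. Compound 3 `CN(C)/N=N/c1ccccc1C(N)=O` awaits measurement. It differs from compound 2 in one place: carbamoyl in place of nitro on an aromatic carbon. Going by the values given here, no step between measured compounds that differ in a single place is available, so the change has to be judged from the values themselves. Compound 1, carrying the carbamoyl group, at 3.26 and compound 2, carrying the nitro group, at 3.28 sit within the scatter of each other, which gives no sign that the swap moves the number. In this assay the expected step is therefore a number 0.03 log units lower from compound 2 to compound 3 (within the scatter), none beyond the scatter. Compound 3 is expected to give 3.25 in this assay, with a range from 2.8 to 3.7.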

Compound 3, logarithm of the reciprocal of the active concentration, log(1/C): 3.31
For compound 3 the middle estimate is 0.06 log units below the measured one; the range from low to high includes it.
By their numbers in this assay, from the lowest: compounds 1, 2 and 3 (each within the scatter of the next).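

In this assay, the direct exchange of nitro for carbamoyl on an aromatic carbon gives a number 0.03 log units higher from compound 2 to compound 3 (within the scatter), so at this position the two groups cannot be told apart on this read-out. The shared core also gains a second single-place comparison, on the chain at the amine nitrogen: hydrogen in place of ethyl on a saturated chain carbon bound to that nitrogen gives a number 0.05 log units higher from compound 1 to compound 3 (within the scatter), and this change cannot be told apart either. No measurement is at hand that bears on either result.

All three compounds lie within the scatter of one another, so neither place has yet been seen to move the number. As far as these compounds go, whether an amine or a carboxylic acid at the aromatic carbon, or a butyl chain on the amine nitrogen, would move it beyond the scatter remains open.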